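The compounds below may be only part of what the source reports. "The series", "measured", "known", "first", "only" and "open" are said of these compounds alone.

Measured so far:
Compound 1 `O=C(CSC(=S)N[C@H]1CCOC1=O)Nc1ccccc1` in a functional assay on EC9706 cells (Homo sapiens) for cytotoxicity, read by MTT assay, with a stated time of 72 h (on this read-out higher numbers stand for weaker inhibition and lower numbers for stronger inhibition), gives > 128000 nM, a limit of the assay.
Compound 2 `COc1ccc(NC(=O)CSC(=S)N[C@H]2CCOC2=O)cc1` in this assay gives > 128000 nM, again a limit of the assay.
Within the data shown here, compound 3 `CCOC(=O)c1ccc(NC(=O)CSC(=S)N[C@H]2CCOC2=O)cc1` in this assay gives 112000 nM, the only value in this set that is a number.

Among the measured compounds shown here, compound 3 therefore stands alone as the single read number; the other two values sit at the limit of > 128000 nM in this assay, at which 2 of the 3 values shown sit. For the measured compounds named here, the step of an at least 1.1-fold lower number from compound 1 to compound 3 (0.05 log units; that floor lies within the scatter) and the step of an at least 1.1-fold lower number from compound 2 to compound 3 (0.05 log units; that floor lies within the scatter) are both floors that lie within the scatter, so no measured step in this set is beyond the scatter.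

Compound 4 `CCCCc1ccc(NC(=O)CSC(=S)N[C@H]2CCOC2=O)cc1` differs from compound 3 in one place: butyl in place of ethoxycarbonyl on an aromatic carbon. Going by the values given here, no measured step exchanges ethoxycarbonyl for butyl, so the change has no direct precedent here; the steps onto compound 3 only show that ethoxycarbonyl gave a number near the limit. With no step beyond the scatter to lean on, the expectation in this assay is a 1.0-fold lower number from compound 3 to compound 4 (0.01 log units; within the scatter), no change beyond the scatter, with a real chance that only a limit is returned.

For compound 4 the estimated value is 110000 nM, expected to lie between 45000 nM and 250000 nM.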

Compound 4, half-maximal inhibitory concentration: 44200 nM
For compound 4 the middle estimate is 2.5-fold (0.40 log units) above the measured one; measured number below the stated range.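

In this assay, among these compounds, the group at this position on the aromatic ring moves the read-out beyond the scatter for the first time: butyl in place of ethoxycarbonyl gives a 2.5-fold lower number from compound 3 to compound 4 (0.40 log units; beyond the scatter). Butyl in place of methoxy gives an at least 2.8-fold lower number from compound 2 to compound 4 (0.46 log units; beyond the scatter), and butyl in place of hydrogen gives an at least 2.8-fold lower number from compound 1 to compound 4 (0.46 log units; beyond the scatter), which makes compound 4 the strongest of the four shown. Both of these last two steps are floors, because each starts from a limit of the assay: the limit of > 128000 nM in this assay, at which 2 of the 4 values shown sit.

Butyl is the only carbon chain shown at this position, and whether a longer chain such as octyl extends the step remains open. As far as these compounds go, how an amine or a carboxylic acid would read at the same place also remains open.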